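Replacing a Chlorophenyl with a Nitrophenyl on the Amide

The compounds below may be only part of what the source reports. "The series", "measured", "known", "first", "only" and "open" are said of these compounds alone.

Compound 2 `NC(=O)c1c(NC(=O)c2ccccc2Cl)sc2c1CCN(Cc1ccc(Cl)cc1Cl)C2` gives 16300 nM in a functional assay on MKN-74 cells (Homo sapiens) for antiproliferative activity, with a stated time of 24 h; on this read-out lower numbers stand for stronger inhibition and higher numbers for weaker inhibition. Compound 1 `NC(=O)c1c(NC(=O)c2ccccc2Cl)sc2c1CCNC2`, which carries hydrogen instead of the 2,4-dichlorobenzyl group on the amine nitrogen in the ring, gives 28700 nM; the two lie within the scatter of each other, as a 1.8-fold lower number from compound 1 to compound 2 (0.25 log units; within the scatter) shows. Compound 3 `NC(=O)c1c(NC(=O)c2cccc([N+](=O)[O-])c2)sc2c1CCN(Cc1ccc(Cl)cc1Cl)C2` differs from compound 2 by 3-nitrophenyl in place of 2-chlorophenyl on a carbonyl carbon. Going by the values given here, the one measured step concerns the amine nitrogen, not the carbonyl carbon, so no measured step bears on this change. Accordingly no step beyond the scatter is expected: a 1.0-fold lower number from compound 2 to compound 3 (0.01 log units; within the scatter). Compound 3 is estimated at 16000 nM, with a range from 5000 nM to 50000 nM.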

Compound 3, half-maximal inhibitory concentration: 16500 nM
Beside the measured number, compound 3's estimate is 1.0-fold (0.01 log units) below it; measured number inside the range.
By their numbers in this assay, from the lowest: compounds 2, 3 and 1 (each within the scatter of the next).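

The change from 2-chlorophenyl to 3-nitrophenyl on the carbonyl carbon amounts to a 1.0-fold higher number from compound 2 to compound 3 (0.01 log units; within the scatter) in this assay and so leaves the number within the scatter, even though the two groups differ in their atoms. Going by these compounds alone, the earlier step concerned only the amine nitrogen, so this is the first reading at the carbonyl position. No supporting data explain why these two groups read alike.

Going by these compounds, whether an amine or a carboxylic acid on the phenyl ring would read differently remains open. So does whether a simple alkyl chain in place of the ring would.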